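Trading a dimethylamino for a carboxy on the pendant ring

The source may report more compounds than this note shows. Statements on the series, on what has been measured and on what is new or still open speak of the compounds shown alone.

Three compounds have been measured in an assay for binding affinity to dual specificity mitogen-activated protein kinase kinase 4 (Homo sapiens), read by KINOMEscan, tested at 100 nM; a lower number here means a stronger effect, a higher number a weaker effect of the compound at the concentration tested:

compound 1, `CCCS(=O)(=O)Nc1ccc(F)c(C(=O)c2n[nH]c3ncc(-c4ccccc4N)cc23)c1F`, gives 23%
compound 2, `CCCS(=O)(=O)Nc1ccc(F)c(C(=O)c2n[nH]c3ncc(-c4cccc(N(C)C)c4)cc23)c1F`, gives 26%
compound 3, `CCCS(=O)(=O)Nc1ccc(F)c(C(=O)c2n[nH]c3ncc(-c4ccc(N(C)C)cc4)cc23)c1F`, gives 2.5%

Compound 3 stands lowest of the three. Its steps to the others are a number 20.5 percentage points lower from compound 1 to compound 3 (beyond the scatter) and a number 23.5 percentage points lower from compound 2 to compound 3 (beyond the scatter), both beyond the scatter, while compounds 1 and 2 sit within the scatter of each other, a number 3 percentage points higher from compound 1 to compound 2 (within the scatter).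

Compound 4, `CCCS(=O)(=O)Nc1ccc(F)c(C(=O)c2n[nH]c3ncc(-c4ccc(C(=O)O)cc4)cc23)c1F`, differs from compound 3 in one place: carboxy in place of dimethylamino on an aromatic carbon.

Going by the values given here, no measured step exchanges the group itself; the measured steps only move the amino-type group around the pendant ring, and the two that reach compound 3 were modest in size. The change to compound 4 keeps the group at the same place on the ring but replaces it with one of a different kind. On this footing, a step of about the size seen in a number 23.5 percentage points lower from compound 2 to compound 3 (beyond the scatter), but in the opposite direction, is expected, with wide uncertainty. For compound 4 the expected step is a number 27.5 percentage points higher from compound 3 to compound 4 (beyond the scatter), and the estimate is 30%, in the range 5% to 75%.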

Compound 4, a percentage reported as activity, at one concentration (the size of the read-out at that concentration, not a potency): 0.1%
For compound 4 the middle estimate is 29.9 percentage points above the measured one, outside the stated range (below it).
By their numbers in this assay, from the lowest: compounds 4 and 3 (each within the scatter of the next); then compounds 1 and 2 (each within the scatter of the next).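

In this assay, exchanging one group for another at the same place on the ring gives a number 2.4 percentage points lower from compound 3 to compound 4 (within the scatter), so dimethylamino and carboxy read alike here, although the earlier compounds had only shown amino-type groups on this ring. The low number is therefore not tied to dimethylamino: 4-carboxyphenyl stands well apart from the other two pendant rings, with a number 25.9 percentage points lower from compound 2 to compound 4 (beyond the scatter) and a number 22.9 percentage points lower from compound 1 to compound 4 (beyond the scatter), and both groups that sit para to a large group, in compound 3 and compound 4, give low numbers. Nothing available explains why two such different groups read alike in this assay.

As far as these compounds go, this read-out comes from one concentration and is not a potency, so it remains open whether compound 3 and compound 4 would still read alike at lower concentrations, where a real difference between them could appear. From the compounds shown here alone, it is also open whether the same place would accept other groups, such as a methyl ester, a primary amide or a plain amine, and whether the carboxy would give a similarly low number if it were moved elsewhere on the ring.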